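The source may report more compounds than this note shows. Statements on the series, on what has been measured and on what is new or still open speak of the compounds shown alone.

Compound 1 `Fc1ccc(-c2noc(C3CCc4c(nnn4-c4ccc(F)cc4)C3)n2)cc1` was tested in a functional assay on U2OS cells with metabotropic glutamate receptor 5 (Homo sapiens) as the target, read by calcium flux (on this read-out higher numbers stand for larger maximal responses and lower numbers for smaller maximal responses), where compound 1 gives 106%. Among the compounds with values here, only one other compound has been measured, and the two stand side by side: compound 2 `CC1(n2nnc3c2CCC(c2nc(-c4ccc(F)cc4)no2)C3)CCOCC1` gives 103% in this assay, and the step of a number 3 percentage points lower from compound 1 to compound 2 (within the scatter) lies within the usual scatter of this measurement. That step put 4-methyloxan-4-yl in place of 4-fluorophenyl on an aromatic nitrogen, so it shows how the read-out answers when the group on that aromatic nitrogen is exchanged.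

Compound 3 `CC(C)(C)Cn1nnc2c1CCC(c1nc(-c3ccc(F)cc3)no1)C2` has not yet been measured. It differs from compound 1 by neopentyl in place of 4-fluorophenyl on an aromatic nitrogen. Within the data shown here, the one measured step that bears on this change is the earlier exchange at the same kind of position, which also replaced 4-fluorophenyl on an aromatic nitrogen and moved the number by a number 3 percentage points lower from compound 1 to compound 2 (within the scatter). On that basis no step beyond the scatter is expected, and the estimated change is a number 6 percentage points lower from compound 1 to compound 3 (within the scatter). Compound 3 is therefore expected to give about 100% in this assay, with a likely range from 82% to 115%.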

Compound 3, largest response reached (reported as percent of maximum), in percent of the reference or control that the assay uses: 108%
Estimate against measurement, compound 3: 8 percentage points below, and the stated range covers the measured number.
By their numbers in this assay, from the lowest: compounds 2, 1 and 3 (each within the scatter of the next).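

Neopentyl in place of 4-fluorophenyl on the aromatic nitrogen gives a number 2 percentage points higher from compound 1 to compound 3 (within the scatter), and neopentyl in place of 4-methyloxan-4-yl on that nitrogen gives a number 5 percentage points higher from compound 2 to compound 3 (within the scatter). Both earlier groups contain a ring and neopentyl has none, so these compounds show that in this assay a ring on this nitrogen is not required for a response within the scatter of compound 1 and compound 2, something the first pair could not show. Nothing available here explains why these three different groups cannot be told apart on this read-out.

The three groups also leave open how far this tolerance extends, for example whether a much smaller methyl group, a longer chain such as n-octyl, or a chain ending in an amine or a carboxylic acid would keep the response within the scatter of these compounds. From the compounds shown here alone, this read-out reports only the largest response reached, so how much of each compound is needed to reach that response also remains open.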